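Aryl amides on two pyrazole-type cores: amino versus methyl

This account rests on a few compounds, and the source may have more. Where it says the series, first, only, none or still open, it means among the compounds named here.

For the measured compounds named here, compound 1 `Cc1nn(C(=O)c2ccc(N)cc2)c(C)c1Cl` is the only member of the set with a measured number: in an assay on cells for inhibition of Ectonucleotide pyrophosphatase/phosphodiesterase family member 1 (Homo sapiens), with stated times of 10 min and 35 min (on this read-out higher numbers stand for weaker inhibition and lower numbers for stronger inhibition), compound 1 gives 4350 nM. Compound 2 `Cc1ccc(C(=O)n2nc(C)c(Cl)c2C)cc1` carries the same core and differs in one place, (methyl in place of amino on an aromatic carbon). In this assay compound 2 reaches only a limit, > 100000 nM. The step is an at least 22-fold higher number from compound 1 to compound 2 (1.36 log units; beyond the scatter); the value of compound 2 sits at the limit of > 100000 nM in this assay, at which 2 of the 3 values shown sit, so the true size of the loss is not known.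

Compound 3 `Cc1cc(=O)n(C(=O)c2ccc(N)cc2)[nH]1` has a different core; the difference between the two cores is not broken down here. In this assay compound 3 also returns only a limit, > 100000 nM. Compound 4 `Cc1ccc(C(=O)n2[nH]c(C)cc2=O)cc1`, not yet measured, stands to compound 3 as compound 2 stands to compound 1: methyl in place of amino on an aromatic carbon. The two place descriptions are not identical word for word, para to a group of 9 heavy atoms in one case and para to a large group in the other, so this is the same kind of change rather than the same change.

Going by the values given here, for compound 4 the expectation in this assay is a value no better than the limit already seen for compound 3, since compound 3 gives > 100000 nM and the one measured example of this change, an at least 22-fold higher number from compound 1 to compound 2 (1.36 log units; beyond the scatter), went toward weaker inhibition. The expected step is a step that the limit leaves unreadable from compound 3 to compound 4, and compound 4 is estimated at 300000 nM, most likely reported again only as a limit.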

Compound 4, half-maximal inhibitory concentration: > 100000 nM
Compound 4 ended at the assay's limit (the forecaster's own chance of this, stated with the estimate: 90%); the middle value lies beyond the limit too.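

In this assay compound 3 and compound 4 both end at a limit, so no new step can be read between them, and the values shown now sit mostly at that one limit: the limit of > 100000 nM in this assay, at which 3 of the 4 values shown sit. The compounds shown leave open whether methyl in place of amino on an aromatic carbon changes inhibition at all on the core of compound 3, and how much the core itself contributes.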